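The source may report more compounds than this note shows. Statements on the series, on what has been measured and on what is new or still open speak of the compounds shown alone.

Compound 1 `CCCCOC(=O)C(=O)C(CC)NC(=O)C(CC(C)C)NC(=O)OCc1ccccc1`: 28000 nM
Compound 2 `CCOC(=O)C(=O)C(CC)NC(=O)C(CC(C)C)NC(=O)C(CC)Oc1ccccc1`: 22000 nM
Compound 3 `CCC(=O)C(=O)[C@H](CC)NC(=O)[C@H](CC(C)C)NC(=O)[C@H](CC(C)C)NC(=O)OCc1ccccc1`: 40000 nM

In a functional assay for inhibition, with Rattus norvegicus as the target, at pH 7.35 (a lower number here means a stronger inhibitor, a higher number a weaker inhibitor), compound 1 stands within the scatter of both compound 2 and compound 3, so the three numbers offer no clear ranking around it. Compound 4 `CCCCCCCCNC(=O)C(=O)C(CC)NC(=O)C(CC(C)C)NC(=O)OCc1ccccc1` keeps the core of compound 1 but carries octylamino in place of butoxy on a carbonyl carbon. Within the data shown here, no measured step isolates this change, so the expectation rests only on the close values of compound 2 at 22000 nM and compound 3 at 40000 nM. A modest step to a lower number in this assay is expected, little beyond the scatter. The expected step is a 1.9-fold lower number from compound 1 to compound 4 (0.27 log units; within the scatter). The estimate for compound 4 is 15000 nM, with a range of 4000 nM to 50000 nM.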

Compound 4, half-maximal inhibitory concentration: 200000 nM
Compound 4: middle estimate off by 13-fold (1.12 log units), on the low side; the measured number lies above the stated range.
By their numbers in this assay, from the lowest: compounds 2, 1 and 3 (each within the scatter of the next); then compound 4.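

In this assay, among these compounds, this position on a carbonyl carbon proves sensitive: octylamino in place of butoxy gives a 7.1-fold higher number from compound 1 to compound 4 (0.85 log units; beyond the scatter) and is the only step here that can be read. That step joins a longer chain to an exchange of oxygen for nitrogen, so it cannot separate the two. No available evidence bears on the reason for the step. On these data alone, whether butylamino, which keeps the four carbons of butoxy, or octyloxy, which keeps the oxygen, would stand nearer compound 1 or compound 4 remains open.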